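Checking a Side-Chain Swap Against an Earlier Step

The source may report more compounds than this note shows. Statements on the series, on what has been measured and on what is new or still open speak of the compounds shown alone.

Three compounds have been measured in a functional assay on the whole organism (Tail, strain ICR) with Mus musculus as the target, in the tail flick test, with a stated time of 60 min, at a dose of 25 umol/kg by the oral route; on this read-out higher numbers stand for a stronger effect at the one dose given and lower numbers for a weaker effect:

Compound 1 `CSCC[C@H](NC(=O)CN(c1nc(Cl)nc2[nH]cnc12)C1CC1)C(=O)OCc1ccccc1` gives 30.8%.
Compound 2 `CC(C)C[C@H](NC(=O)CN(c1nc(Cl)nc2[nH]cnc12)C1CC1)C(=O)OCc1ccccc1` gives 27.3%.
Compound 3 `CC(C)C[C@H](NC(=O)CN(c1ncnc2c1ncn2C1CCCCO1)C1CC1)C(=O)OCc1ccccc1` gives 34.2%.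

Compounds 1 and 2 share one core and differ only in the side chain next to the ester: (methylsulfanyl)methyl in place of isopropyl on a saturated chain carbon, two bonds along the chain from an amide-type nitrogen and a carbonyl carbon. That change made a step of a number 3.5 percentage points higher from compound 2 to compound 1 (within the scatter), so the two values cannot be told apart with confidence. Compound 3 carries a different core from compound 2; how the two cores differ is not broken down here. All three numbers lie within the scatter of one another, so none can be called the stronger.

Compound 4 `CSCC[C@H](NC(=O)CN(c1ncnc2c1ncn2C1CCCCO1)C1CC1)C(=O)OCc1ccccc1` is still unmeasured. It is compound 3 with the same change already seen between compounds 2 and 1: (methylsulfanyl)methyl in place of isopropyl on a saturated chain carbon, two bonds along the chain from an amide-type nitrogen and a carbonyl carbon. Because the earlier step of a number 3.5 percentage points higher from compound 2 to compound 1 (within the scatter) stayed within the scatter, the step from compound 3 to compound 4 is expected to be small as well, about a number 2.8 percentage points higher from compound 3 to compound 4 (within the scatter) in this assay. Compound 4 is therefore estimated at 37%, most likely between 25% and 50%.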

Compound 4, a percentage reported as activity, at one dose (the size of the read-out at that dose, not a potency): 41%
Estimate against measurement, compound 4: 4 percentage points below, within the range that was stated.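

Putting (methylsulfanyl)methyl in place of isopropyl on the core of compound 3 gives, in this assay, a number 6.8 percentage points higher from compound 3 to compound 4 (within the scatter). Set beside the same change on the core of compound 2, the two steps cannot be told apart, so as far as this read-out can tell, the change carries over from one core to the other without a detectable difference: the same change on two cores in this assay, a number 3.5 percentage points higher (within the scatter) from compound 2 to compound 1 and a number 6.8 percentage points higher (within the scatter) from compound 3 to compound 4, 3.3 percentage points apart, within the scatter of two such steps. This does not show that the change truly strengthens the effect on either core, and two pairs of compounds tested at a single dose say nothing about potency or about how the change would behave on any further core.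

The compounds shown leave open whether a quite different group on this saturated chain carbon, such as an amine, a carboxylic acid or a longer chain, would move the read-out beyond the scatter. They also leave open whether any such group would behave alike on both cores.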